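This account rests on a few compounds, and the source may have more. Where it says the series, first, only, none or still open, it means among the compounds named here.

Of the compounds shown here, two have been measured in an assay on HEK293 cells for inhibition of Steryl-sulfatase (Homo sapiens), tested at 0.1 uM; on this read-out higher numbers stand for a stronger effect at the one concentration tested and lower numbers for a weaker effect. Compound 1, with structure `CCN(Cc1ccc(Br)cc1)c1ccc(C(=O)N2CCc3ccc(OS(N)(=O)=O)cc3C2)cc1`, gives 78.2% in this assay, the higher of the two numbers. Within the data shown here, compound 2, with structure `CCCN(CCC)c1cccc(C(=O)N2CCc3ccc(OS(N)(=O)=O)cc3C2)c1`, gives 8.3% in this assay, a much lower number and well beyond the usual scatter; these two differ in several places at once, so no single step connects them.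

Compound 3, with structure `CCN(Cc1cccc(Br)c1)c1ccc(C(=O)N2CCc3ccc(OS(N)(=O)=O)cc3C2)cc1`, has not yet been measured. It differs from compound 1 only in how the same atoms are joined: 3-bromophenyl in place of 4-bromophenyl on a saturated chain carbon bound to a nitrogen on an aromatic ring. Among the measured compounds shown here, no measured pair shows a change of this kind, so its effect can only be estimated from compound 1 itself. Because compound 1 reaches 78.2% with the 4-bromophenyl group, the 3-bromophenyl arrangement is expected to keep most of that effect, with a modest drop somewhat more likely than a gain. This step is expected to be small and downward, a number 10.2 percentage points lower from compound 1 to compound 3 (beyond the scatter). Compound 3 is therefore expected to give about 68%, within a range from 45% to 85%.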

Compound 3, a percentage reported as inhibition, at one concentration (the size of the read-out at that concentration, not a potency): 80.2%
Estimate against measurement, compound 3: 12.2 percentage points below; measured number inside the range.
By their numbers in this assay, from the lowest: compound 2; then compounds 1 and 3 (each within the scatter of the next).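

In this assay, 3-bromophenyl in place of 4-bromophenyl on a saturated chain carbon bound to a nitrogen on an aromatic ring gives a number 2 percentage points higher from compound 1 to compound 3 (within the scatter), so this read-out does not separate the two arrangements of the bromine on the ring. Compound 1 alone could not show this: the high number seen with 4-bromophenyl is not lost when the same atoms are joined as 3-bromophenyl, although a single concentration gives the size of the effect and not a potency, so a difference in potency could remain hidden. Nothing at hand accounts for the two arrangements reading alike.

Going by these compounds, it remains open whether the bromine is needed at all, which an unsubstituted phenyl ring or a chlorine or methoxy group on the ring in its place would help to answer. On these data alone, it is also open how much the ethyl group on the nitrogen contributes, which a longer chain such as propyl, or a plain amine hydrogen there, would help to show.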